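Extending the Chain End of a Sulfonamide Peptide Inhibitor

The source may report more compounds than this note shows. Statements on the series, on what has been measured and on what is new or still open speak of the compounds shown alone.

Compound 1, `CC(C)C[C@H](NC(=O)CNC(=O)CC[C@H](NS(=O)(=O)c1ccc(Cl)c(C(F)(F)F)c1)C(=O)O)C(=O)N[C@H](C(N)=O)C(C)C`, gives 56 nM in an assay on isolated protein for inhibition of Matrilysin (Homo sapiens), read by fluorescence, with a stated time of 15 min; a lower number here means a stronger inhibitor, a higher number a weaker inhibitor. It stands as the lowest of the three numbers measured: compound 2, `CSCC[C@H](NC(=O)[C@H](CC(C)C)NC(=O)CNC(=O)CC[C@H](NS(=O)(=O)c1ccc(Cl)c(C(F)(F)F)c1)C(=O)O)C(N)=O`, gives 120 nM, and compound 3, `CSCC[C@H](NC(=O)[C@H](CC(C)C)NC(=O)[C@H](CC(N)=O)NC(=O)CC[C@H](NS(=O)(=O)c1ccc(Cl)c(C(F)(F)F)c1)C(=O)O)C(N)=O`, gives 7500 nM. The step from compound 1 to compound 2, a 2.1-fold higher number from compound 1 to compound 2 (0.33 log units; beyond the scatter), is a modest loss; the step from compound 2 to compound 3, a 63-fold higher number from compound 2 to compound 3 (1.80 log units; beyond the scatter), is a large one.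

Compound 4, `CC(C)C[C@H](NC(=O)CNC(=O)CC[C@H](NS(=O)(=O)c1ccc(Cl)c(C(F)(F)F)c1)C(=O)O)C(=O)N[C@H](C(=O)N1CCC[C@H]1C(N)=O)C(C)C`, differs from compound 1 as follows: 2-carbamoylpyrrolidin-1-yl in place of amino on a carbonyl carbon. This change sits on a carbonyl carbon whose other neighbours are a saturated chain carbon, so the shared core is lengthened at its end rather than altered within, as the step from compound 2 to compound 3 did. Neither measured step matches this change closely. The modest step from compound 1 to compound 2 suggests that changes at this end of the core are tolerated, while the large step from compound 2 to compound 3 warns that adding mass to the chain can cost much. Weighing these, compound 4 is expected to show a small weakening, a 1.6-fold higher number from compound 1 to compound 4 (0.21 log units; within the scatter), and its estimate in this assay is 90 nM, within 30 nM to 300 nM.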

Compound 4, half-maximal inhibitory concentration: 19 nM
For compound 4 the middle estimate is 4.7-fold (0.68 log units) above the measured one; the whole stated range lies above it.
By their numbers in this assay, from the lowest: compound 4; then compound 1; then compound 2; then compound 3.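

In this assay, exchanging amino for 2-carbamoylpyrrolidin-1-yl on a carbonyl carbon brought a 2.9-fold lower number from compound 1 to compound 4 (0.47 log units; beyond the scatter), so this larger group is not merely tolerated at this position. Both earlier steps raised the number, and both were changes on a saturated chain carbon; this is the first step shown that lowers it, and the carbamoyl group is retained within the entering group. No evidence on hand accounts for the gain.

The compounds shown leave open whether the gain needs the pyrrolidine ring, which an open-chain group such as a glycine amide could test, or the carbamoyl group, which a carboxylic acid or a plain unsubstituted pyrrolidin-1-yl could test. They also leave open whether the same exchange would lower the number on compound 2, whose 2-(methylsulfanyl)ethyl group replaces the isopropyl of compound 1.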